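Chalcone series on a shared core: chloro to methoxy

The source may report more compounds than this note shows. Statements on the series, on what has been measured and on what is new or still open speak of the compounds shown alone.

Measured so far:
compound 1 `CC1(C)Cc2c(OCc3ccccc3)ccc(C(=O)/C=C/c3cn(-c4ccccc4)nc3-c3ccc([N+](=O)[O-])cc3)c2O1` gives > 100000 nM
compound 2 `CC1(C)Cc2c(ccc(C(=O)/C=C/c3ccccc3)c2OCc2ccccc2)O1` gives > 100000 nM
compound 3 `CC1(C)Cc2c(OCc3ccccc3)ccc(C(=O)/C=C/c3ccc(Cl)cc3)c2O1` gives > 100000 nM

These three compounds share one core and differ in the group carried on the alkene end of the chain. In a functional assay on PC-3 cells (Homo sapiens) for antiproliferative activity, read by MTT assay, with a stated time of 48 h (a higher number here means a weaker inhibitor, a lower number a stronger inhibitor), compound 1 returns a limit, > 100000 nM, not a number. Compound 2 also returns a limit in this assay, > 100000 nM. Compound 3, the starting point of the step followed here, likewise sits at a limit in this assay, > 100000 nM. Where compound 3 stands is therefore fixed only from one side: it rests on (the limit of > 100000 nM in this assay, at which 3 of the 3 values shown sit), together with the two other compounds.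

The step leads to compound 4 `COc1ccc(/C=C/C(=O)c2ccc(OCc3ccccc3)c3c2OC(C)(C)C3)cc1`, which has not yet been tested. The change is small: methoxy in place of chloro on an aromatic carbon. Going by the values given here, no step between measured compounds is available to calibrate it, and nothing among the three measured compounds shows any group on this ring moving a value away from the limit. A shift beyond the scatter in either direction is thus not expected; the step from compound 3 to compound 4 is estimated as a step that the limit leaves unreadable from compound 3 to compound 4. Compound 4 is expected to give 150000 nM in this assay, with a range of 30000 nM to 1000000 nM.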

Compound 4, half-maximal inhibitory concentration: 13500 nM
Compound 4: middle estimate off by 11-fold (1.05 log units), on the high side; the measured number lies below the stated range.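

In this assay, going by these compounds alone, methoxy in place of chloro is the first change here that brings a value off the limit, and it reads as an at least 7.4-fold lower number from compound 3 to compound 4 (0.86 log units; beyond the scatter). The group carried para to a large group on this aromatic ring therefore does matter in this assay: this one change turns a compound that gives only a limit into one that gives a number. The real size of the step remains unknown, however, because compound 3 offers no number to start from: the limit of > 100000 nM in this assay, at which 3 of the 4 values shown sit.

The compounds shown leave open whether other groups at this place, such as a hydroxyl, an amine or a longer ethoxy chain, would lower the number further or return it to the limit. A single step also cannot tell whether the same change from 4-chlorophenyl to 4-methoxyphenyl would act in the same way on a different core or with the benzyloxy group moved elsewhere.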